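This account rests on a few compounds, and the source may have more. Where it says the series, first, only, none or still open, it means among the compounds named here.

Going by the values given here, compound 1 `C/C(=N\OC(C)C)c1ccc(Sc2cc(F)cc(C3CCOCC3)c2)cc1` is the weaker of the two compounds measured so far in a functional assay (blood) for inhibition, with Homo sapiens as the target; a lower number here means a stronger inhibitor, a higher number a weaker inhibitor: compound 1 gives 920 nM, the highest of the two numbers. Among the compounds with values here, its only neighbour is compound 2 `CCOC(=O)/C(=N\O)c1ccc(Sc2cc(F)cc(C3CCOCC3)c2)cc1`, which in this assay gives 170 nM; that step, a 5.4-fold lower number from compound 1 to compound 2 (0.73 log units; beyond the scatter), comes from a different change, one on an aromatic carbon, and does not touch the oxygen that is altered here.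

Compound 3 `C/C(=N\OCCSc1nnc(C)s1)c1ccc(Sc2cc(F)cc(C3CCOCC3)c2)cc1` differs from compound 1 by 2-((5-methyl-1,3,4-thiadiazol-2-yl)sulfanyl)ethyl in place of isopropyl on an oxygen. The isopropyl leaves and the 2-((5-methyl-1,3,4-thiadiazol-2-yl)sulfanyl)ethyl enters on the oxygen whose other neighbour is the double-bonded nitrogen.

Within the data shown here, no measured step bears directly on this exchange: the one step known runs on the other side of the core, and nothing shows how this oxygen tolerates a larger group. The expectation therefore rests on little, and the step expected is a 1.2-fold lower number from compound 1 to compound 3 (0.06 log units; within the scatter), with a wide range around it. For compound 3 the estimate in this assay is 800 nM, expected to fall between 200 nM and 3000 nM.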

Compound 3, half-maximal inhibitory concentration: 230 nM
Estimate against measurement, compound 3: 3.5-fold (0.54 log units) above; measured number inside the range.
By their numbers in this assay, from the lowest: compounds 2 and 3 (each within the scatter of the next); then compound 1.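

Going by these compounds alone, compound 3 gives the first reading on the oxygen whose other neighbour is the double-bonded nitrogen, and in this assay this position accepts far more than a small isopropyl. Exchanging isopropyl for 2-((5-methyl-1,3,4-thiadiazol-2-yl)sulfanyl)ethyl, a much larger group that brings a five-membered aromatic ring with 3 hetero atoms, gives a 4.0-fold lower number from compound 1 to compound 3 (0.60 log units; beyond the scatter), so the longer group on this oxygen comes with stronger inhibition, not weaker, in this one pair. The data offer no measured explanation for this step.

Going by these compounds, one exchange cannot separate the parts of the entering group, so it remains open whether the gain follows the ring, the sulfur in the chain or simply the added length, and whether a plain ethyl, a 2-methoxyethyl or a 2-aminoethyl chain on the same oxygen would give a similar number. On these data alone, it is equally open whether the same exchange on this oxygen would give a similar step with a different group on the other side of the double-bonded nitrogen, such as the ethyl ester carried by compound 2.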